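A few compounds are considered here, and "the series" means these few. Any claim that something is new, unique, unknown or untested is made for them only; others in the source may bear on it.

Compound 1 `O=C(/C=C\Nc1ccc(F)cc1)c1nc(-c2ccc(F)cc2)n2ccccc12` is the reference point of this small set. Within the data shown here, in a functional assay on MDA-MB-231 cells (Homo sapiens) for cytotoxicity, read by MTT assay, with a stated time of 48 h (a lower number here means a stronger inhibitor, a higher number a weaker inhibitor), compound 1 gives 25100 nM, the only number available in this set. Compound 2 `O=C(/C=C\Nc1ccc(F)cc1)c1nc(-c2ccc(C(F)(F)F)cc2)n2ccccc12` carries trifluoromethyl in place of fluoro on an aromatic carbon. In this assay compound 2 is reported only as a limit of > 30000 nM. That limit of > 30000 nM in this assay, at which 1 of the 2 values shown sits, means the step of an at least 1.1-fold higher number from compound 1 to compound 2 (0.07 log units; that floor lies within the scatter) cannot be sized beyond its floor.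

Compound 3 `O=C(/C=C\Nc1ccc(Cl)cc1)c1nc(-c2ccc(F)cc2)n2ccccc12` differs from compound 1 by chloro in place of fluoro on an aromatic carbon. Among the measured compounds shown here, no measured step touches this position: the only step known, from compound 1 to compound 2, concerns the other aryl ring and a different group, and its floor lies within the scatter. With nothing pointing either way, no step beyond the scatter is expected in this assay. Compound 3 is therefore estimated at 22000 nM, within 10000 nM to 45000 nM, a step of a 1.1-fold lower number from compound 1 to compound 3 (0.06 log units; within the scatter) that stays within the usual scatter.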

Compound 3, half-maximal inhibitory concentration: 4250 nM
Compound 3: the middle estimate sits 5.2-fold (0.71 log units) above what was measured, and the stated range ends above it.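

In this assay, among these compounds, the halogen on the ring of the amino group proves to matter: the change from (4-fluorophenyl)amino to (4-chlorophenyl)amino gives a 5.9-fold lower number from compound 1 to compound 3 (0.77 log units; beyond the scatter), and this is the first step in the set that can be sized and that lies beyond the scatter. The earlier step from compound 1 to compound 2 concerned the other aromatic ring and could be read only as far as its floor, so it gave no sign that the exchange of one halogen atom for another could move the number on the shared core. Nothing shown accounts for this gain in measured terms, and the one limit at hand belongs to compound 2 and says nothing about the chloro change.

As far as these compounds go, it remains open whether the gain continues with bromo or iodo at the same place, or whether a methoxy group or an amine there would keep it. From the compounds shown here alone, it is equally open whether chloro in place of the fluoro of the 4-fluorophenyl group on the other ring would give a similar step.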